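This account rests on a few compounds, and the source may have more. Where it says the series, first, only, none or still open, it means among the compounds named here.

The measured compounds:
Compound 1, `Cn1c(COc2cccc(C(=O)O)c2)nc2ccc(Oc3ccc(F)cc3)nc21`, gives 1.5.
Compound 2, `Cc1ccc(Oc2cc3c(cn2)nc(COc2cccc(C(=O)O)c2)n3C)cc1`, gives 1.
Compound 3, `Cc1ccnc(Oc2ccc3nc(COc4cccc(C(=O)O)c4)n(C)c3c2)c1`, gives 0.8.

All three were run in a physicochemical assay for lipophilicity, read by LC-MS, in phosphate buffer, measured as octanol-water partition, with a stated time of 30 min, at pH 7.4, tested at 200 mM; on this read-out lower numbers stand for lower lipophilicity and higher numbers for higher lipophilicity. Compound 3 has the lowest of the three numbers. Its nearest neighbour is compound 2, whose value lies higher by an amount that falls within the usual scatter, so the two cannot be told apart on this read-out. Compound 1 stands furthest away, higher by an amount beyond the scatter, so compound 1 is the more lipophilic of that pair.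

Compound 4, `Cc1cc(Cl)cnc1Oc1ccc2nc(COc3cccc(C(=O)O)c3)n(C)c2c1`, has not yet been measured in this assay. It differs from compound 3 in a single place: 5-chloro-3-methylpyridin-2-yl in place of 4-methylpyridin-2-yl on an oxygen on an aromatic ring. The group that enters carries a chlorine, which the group that leaves lacks. Within the data shown here, no pair of measured compounds here differs in just one place, so no measured step is available to guide the size of the shift. The expectation is a moderate rise, beyond the scatter: the step from compound 3 to compound 4 is estimated as a number 0.60 log units higher from compound 3 to compound 4 (beyond the scatter). Compound 4 is therefore expected to give about 1.4, with a likely range from 1 to 1.8.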

Compound 4, distribution coefficient: 1.8
Estimate against measurement, compound 4: 0.40 log units below; low and high end bracket the measured number.
By their numbers in this assay, from the lowest: compounds 3 and 2 (each within the scatter of the next); then compounds 1 and 4 (each within the scatter of the next).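

In this assay, among these compounds, the swap of 4-methylpyridin-2-yl for 5-chloro-3-methylpyridin-2-yl on an oxygen on an aromatic ring gives the only measured step between compounds that differ in one place, a number 1.00 log units higher from compound 3 to compound 4 (beyond the scatter) and this shows that the number responds to a change at this position by more than repeat measurements would scatter. The change is not a single alteration, since the entering group carries a chlorine that the leaving group lacks and its methyl group also stands at a different place on the ring, so the step belongs to both alterations taken together. No evidence on the cause of this step is available here.

The compounds shown do not separate the share of the chlorine from the share of the moved methyl group, which 3-methylpyridin-2-yl without chlorine or 5-chloro-4-methylpyridin-2-yl could begin to do. On these data alone, it also stays open how the number would respond to a different kind of group on that ring at the same place, such as an amine or a carboxylic acid.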